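Swapping methoxy for tert-butyl on a fluorinated series

This account rests on a few compounds, and the source may have more. Where it says the series, first, only, none or still open, it means among the compounds named here.

Measured in a functional assay on HeLa cells (Homo sapiens) for cytotoxicity, read by MTT assay, with a stated time of 24 h; on this read-out lower numbers stand for stronger inhibition and higher numbers for weaker inhibition:
- Compound 1 `COc1ccc(/C=C2\CN(C)C/C(=C\c3ccccc3F)C2=O)cc1`: 23500 nM
- Compound 2 `COc1ccc(/C=C2\CN(C)C/C(=C\c3ccccc3F)C2=O)cc1OC`: 14400 nM
- Compound 3 `COc1cc(/C=C2\CN(C)C/C(=C\c3ccccc3F)C2=O)cc(OC)c1`: 5450 nM

Compound 1, at 23500 nM, sits with compound 2 at the upper end of these three numbers, as the two lie within the scatter of each other. Compared with compound 1, compound 3 has a clearly lower number, at 5450 nM.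

The next compound to be tested is compound 4 `CN1C/C(=C\c2ccc(C(C)(C)C)cc2)C(=O)/C(=C/c2ccccc2F)C1`. It keeps the shared core of compound 1 but carries tert-butyl in place of methoxy on an aromatic carbon.

Among the measured compounds shown here, only one measured step changes a single place, a 1.6-fold lower number from compound 1 to compound 2 (0.21 log units; within the scatter). It adds a methoxy on an aromatic carbon and stays within the scatter. For the measured compounds named here, no measured compound carries tert-butyl, so the data offer only weak guidance for this swap. The gap between the values of compound 1 and compound 3 does show that changes on this side of the molecule can matter, so the range must stay wide.

The expected result is therefore no shift beyond the scatter, with a 1.6-fold lower number from compound 1 to compound 4 (0.19 log units; within the scatter) as the estimated step in this assay. For compound 4 the estimated value is 15000 nM, with an expected range from 5000 nM to 45000 nM.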

Compound 4, half-maximal inhibitory concentration: 15500 nM
Estimate against measurement, compound 4: 1.0-fold (0.01 log units) below, within the range that was stated.
By their numbers in this assay, from the lowest: compound 3; then compounds 2, 4 and 1 (each within the scatter of the next).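

Putting tert-butyl in place of methoxy on this aromatic carbon gives a 1.5-fold lower number from compound 1 to compound 4 (0.18 log units; within the scatter) in this assay and so leaves the number within the scatter. Among the compounds shown here, until now, the only single-place step at this ring had added a methoxy; this one takes the methoxy away altogether, along with its oxygen and hydrogen-bond acceptor, and brings in a larger, all-carbon group with more heavy atoms. For this pair, then, neither that oxygen nor the smaller size of the methoxy is needed to keep the number where it stands, and this position tolerates two quite different groups with no shift that can be told from the scatter. No measurement shown here explains why the number holds across this swap.

What an amine or a carboxylic acid would do on this aromatic carbon stays open, since only methoxy and tert-butyl are shown at this place. Going by these compounds, it is also open whether tert-butyl would leave the number unchanged on the ring pattern of compound 3, which gives 5450 nM in this assay and differs from compound 1 in more than a single step of this kind.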